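A few compounds are considered here, and "the series" means these few. Any claim that something is new, unique, unknown or untested is made for them only; others in the source may bear on it.

Compound 1, `O=C(O)CC/C=C1\C[C@H]2C[C@@H](O)[C@H](/C=N/NC(=O)Nc3cccc(Cl)c3)[C@H]2C1`, gives 5200 nM in a functional assay on a cell-free system (plasma) for agonist activity at thromboxane A2 receptor (Homo sapiens); a higher number here means a weaker inhibitor, a lower number a stronger inhibitor.
Compound 2, `O=C(O)COC/C=C1/C[C@H]2C[C@@H](O)[C@H](/C=N/NC(=O)Nc3cccc(Cl)c3)[C@H]2C1`, gives 180 nM in this assay.
Compound 3, `O=C(O)CCC/C=C1/C[C@H]2CC[C@H](/C=N/NC(=O)Nc3ccc(Cl)c(Cl)c3)[C@H]2C1`, gives 1800 nM in this assay.

Among these three numbers, compound 3 stands second highest. Its nearest neighbour is compound 1, whose number is higher, and the gap between them lies beyond the scatter. Furthest from it is compound 2, whose number is lower, again by a gap beyond the scatter. Compound 1 and compound 2 differ in more than one respect, so their pair on its own cannot be read as a clean test of any single change.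

The step now followed leads from compound 3 to compound 4, `O=C(O)CCC/C=C1\C[C@H]2CC[C@H](/C=N/NC(=O)Nc3ccc(Cl)c(Cl)c3)[C@H]2C1`. Here (the two compounds have the same atoms and bonds and differ only in configuration as drawn: 1 of 5 stereo elements differ; a double bond is drawn Z in compound 3 and E in compound 4). No pair of measured compounds differs in this one respect alone, so there is no shown step of this kind to lean on, and neither the size nor the direction of its effect in this assay can be read from the numbers at hand. A change of geometry at a double bond in the chain that carries the acid can move potency either way, and an expected step of moderate size, in an uncertain direction, is the most that can be said.

On that basis compound 4 is estimated at 2500 nM, within a range from 500 nM to 12000 nM, which corresponds to an expected step of a 1.4-fold higher number from compound 3 to compound 4 (0.14 log units; within the scatter).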

Compound 4, half-maximal inhibitory concentration: 9000 nM
Beside the measured number, compound 4's estimate is 3.6-fold (0.56 log units) below it; measured number inside the range.
By their numbers in this assay, from the lowest: compound 2; then compound 3; then compounds 1 and 4 (each within the scatter of the next).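

In this assay, the set now holds its first clean single-change comparison, and it shows that the geometry of the double bond in the chain carrying the acid matters: a 5.0-fold higher number from compound 3 to compound 4 (0.70 log units; beyond the scatter). A lower number means a stronger inhibitor here, so compound 3, with the double bond drawn Z, is the stronger of this pair, and compound 4, with it drawn E, is the weaker. With the atoms and bonds identical, the shift can be assigned to this one double bond, because nothing else separates the two structures: the fact that compounds 3 and 4 differ only in the configuration as drawn

As far as these compounds go, whether the same geometry is favoured, and by a similar margin, in compounds carrying a hydroxyl group on the core, such as compound 1 and compound 2, remains open, as these two do not form a matched pair with either compound 3 or compound 4. Also open, from the compounds shown here alone, is how the potency would respond to a fully saturated chain with no double bond at that position, or to a tetrazole in place of the carboxylic acid.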